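The source may report more compounds than this note shows. Statements on the series, on what has been measured and on what is new or still open speak of the compounds shown alone.

Measured so far:
- compound 1 `O=C(Nc1cccc(-n2cc(-c3ccncc3)c(-c3cc(O)cc(Cl)c3)n2)c1)Nc1ccc(Cl)c(Cl)c1`: 85%
- compound 2 `COc1cc(Cl)cc(-c2nn(-c3cccc(NC(=O)Nc4cc(C(F)(F)F)cc(C(F)(F)F)c4)c3)cc2-c2ccncc2)c1`: 101%

In a functional assay on RXF 393 cells (Homo sapiens) for inhibition, read by sulforhodamine B assay, with a stated time of 48 h, tested at 0.1 uM (on this read-out lower numbers stand for a stronger effect and higher numbers for a weaker effect at the one concentration tested), compound 1 stands lowest of the two numbers; the nearest, compound 2, lies higher by a gap beyond the scatter. Compound 3 `COc1cc(Cl)cc(-c2nn(-c3cccc(NC(=O)Nc4ccc(Cl)c(Cl)c4)c3)cc2-c2ccncc2)c1` is not yet measured. It differs from compound 1 by methyl in place of hydrogen on an oxygen on an aromatic ring. Among the compounds with values here, no measured pair shows this change on its own; compound 2 also carries the methoxy, with a different urea partner, and gives the higher number. Expected for compound 3 is a modest move upward, a number 7 percentage points higher from compound 1 to compound 3 (within the scatter), at the edge of the scatter. The estimate for compound 3 is 92%, with a range of 76% to 106%.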

Compound 3, a percentage reported as activity, at one concentration (the size of the read-out at that concentration, not a potency): 101%
The estimate for compound 3 lay 9 percentage points below the measured number; the measured number falls inside the stated range.
By their numbers in this assay, from the lowest: compound 1; then compounds 2 and 3 (each within the scatter of the next).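

In this assay, within the data shown here, the only one-place pair isolates hydroxy to methoxy on an oxygen on an aromatic ring, giving a number 16 percentage points higher from compound 1 to compound 3 (beyond the scatter) at this one concentration. The lower number therefore goes with the free hydroxy in this pair, while the methoxy compounds, compound 2 at 101% and compound 3 at 101%, lie within the scatter of each other. No evidence here bears on the reason for this step.

From the compounds shown here alone, whether an amine or a carboxylic acid in place of the hydroxy would give a still lower number remains open. Also open, going by these compounds, is whether the same step holds with the urea partner of compound 2.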